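Fluorophenyl change from compound 1 to compound 3

This account rests on a few compounds, and the source may have more. Where it says the series, first, only, none or still open, it means among the compounds named here.

Compound 1 `CN1C/C(=C\c2cccc([N+](=O)[O-])c2)C(=O)/C(=C/c2ccccc2F)C1` gives 3890 nM
Compound 2 `COc1cc(/C=C2\CN(C)C/C(=C\c3ccc(Br)cc3)C2=O)cc(OC)c1OC` gives 12400 nM

Both values come from a functional assay on K562 cells (Homo sapiens) for cytotoxicity, read by MTT assay, with a stated time of 24 h; on this read-out lower numbers stand for stronger inhibition and higher numbers for weaker inhibition. Compound 1 has the lower number of the two, and its gap to compound 2 lies beyond the scatter. Compound 3 `CN1C/C(=C\c2ccc(F)cc2)C(=O)/C(=C/c2cccc([N+](=O)[O-])c2)C1` has not been measured. It differs from compound 1 as follows: 4-fluorophenyl in place of 2-fluorophenyl on a double-bonded chain carbon bound to a double-bonded ring carbon. Within the data shown here, no measured pair shows a change of this kind, so the expectation rests on compound 1 alone. The estimated step is a 1.2-fold higher number from compound 1 to compound 3 (0.06 log units; within the scatter), expected to stay within the scatter. For compound 3 the expected value is 4500 nM, with an estimated range of 1700 nM to 11000 nM.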

Compound 3, half-maximal inhibitory concentration: 11300 nM
Compound 3: middle estimate off by 2.5-fold (0.40 log units), on the low side; the whole stated range lies below it.
By their numbers in this assay, from the lowest: compound 1; then compounds 3 and 2 (each within the scatter of the next).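

In this assay, 4-fluorophenyl in place of 2-fluorophenyl gives a 2.9-fold higher number from compound 1 to compound 3 (0.46 log units; beyond the scatter) on the shared core, so this position responds to where the fluorine sits, even though the group that leaves and the group that enters hold the same atoms. This is a single pair, and no measurement at hand accounts for the difference. Open, going by these compounds, is how an unsubstituted phenyl or an aminophenyl at this place would compare with compound 1. Also open, on these data alone, is whether the same fluorine change gives a similar step with other groups elsewhere on the core.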